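This account rests on a few compounds, and the source may have more. Where it says the series, first, only, none or still open, it means among the compounds named here.

Of the compounds shown here, three that share one core have been measured in a functional assay on CHO-K1 cells with Glucose-dependent insulinotropic receptor (Homo sapiens) as the target, read by a luciferase reporter, with a stated time of 5 h; on this read-out lower numbers stand for smaller maximal responses and higher numbers for larger maximal responses. Compound 1 `COC(=O)N1CCC(Oc2ncnc3c2CCN3c2ccc(S(C)(=O)=O)cc2F)CC1` gives 119%. Compound 2 `CCCCOC(=O)N1CCC(Oc2ncnc3c2CCN3c2ccc(S(C)(=O)=O)cc2F)CC1` gives 131%. Compound 3 `CC(C)SC(=O)N1CCC(Oc2ncnc3c2CCN3c2ccc(S(C)(=O)=O)cc2F)CC1` gives 138%, the highest of the three numbers, although its gap to compound 2 is within the usual scatter. The measured steps were a number 12 percentage points higher from compound 1 to compound 2 (beyond the scatter), a number 19 percentage points higher from compound 1 to compound 3 (beyond the scatter) and a number 7 percentage points higher from compound 2 to compound 3 (within the scatter). Compound 4 `CN(C)S(=O)(=O)N1CCC(Oc2ncnc3c2CCN3c2ccc(S(C)(=O)=O)cc2F)CC1` has not yet been measured; it differs from compound 3 in one place: dimethylsulfamoyl in place of (isopropylsulfanyl)carbonyl on an amine nitrogen in a ring. Among the measured compounds shown here, none of the measured steps makes a change of this kind: all three kept a carbonyl on the amine nitrogen in a ring and altered only what is attached to that carbonyl, and the two steps beyond the scatter were modest rises. There is thus no direct guide, since the group entering compound 4 is a departure from the carbonyl-bearing groups seen so far. A number close to the earlier ones is expected, with a step estimated as a number 13 percentage points lower from compound 3 to compound 4 (beyond the scatter). Compound 4 is therefore expected to give 125%, in a range from 100% to 145%.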

Compound 4, largest response reached (reported as percent of maximum), in percent of the reference or control that the assay uses: 68%
Estimate against measurement, compound 4: 57 percentage points above, and the stated range ends above it.
By their numbers in this assay, from the lowest: compound 4; then compound 1; then compounds 2 and 3 (each within the scatter of the next).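

Placed on the amine nitrogen in a ring, the group decides far more of the maximal response in this assay than the earlier changes to what sits on the carbonyl suggested: dimethylsulfamoyl gives a number 70 percentage points lower from compound 3 to compound 4 (beyond the scatter) and a number 63 percentage points lower from compound 2 to compound 4 (beyond the scatter) and also a number 51 percentage points lower from compound 1 to compound 4 (beyond the scatter). So the response at this position tolerates the carbonyl-bearing groups shown, but it does not carry over to this sulfur-linked group, even though (isopropylsulfanyl)carbonyl and dimethylsulfamoyl match in heavy atoms and hydrogen-bond acceptors and neither has a ring or a net charge. Nothing available here explains the drop.

On these data alone, it remains open whether the sulfonyl link or the dimethylamine end accounts for the change. A methanesulfonyl group and a dimethylcarbamoyl group on the same nitrogen would separate these two parts.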